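The source may report more compounds than this note shows. Statements on the series, on what has been measured and on what is new or still open speak of the compounds shown alone.

In an assay on isolated protein for inhibition of GMP reductase 2 (Homo sapiens), read by spectrophotometry (on this read-out higher numbers stand for weaker inhibition and lower numbers for stronger inhibition), compound 3 `C[C@H](Oc1cccc(Cl)c1Cl)C(=O)Nc1ccc2oc(-c3ccc(O)cc3)nc2c1` gives only a limit, > 5000 nM. Compound 1 `COc1ccc(-c2nc3cc(NC(=O)[C@H](C)Oc4cccc(F)c4F)ccc3o2)cc1` likewise gives a limit in this assay, > 5000 nM. Compound 2 `C[C@H](Oc1cccc(F)c1F)C(=O)Nc1ccc2oc(-c3ccncc3)nc2c1` also gives a limit, > 5000 nM. Within the data shown here, the one step within the measured set, a step that the two limits leave unreadable from compound 1 to compound 2, therefore carries no readable size. Compound 4 `C[C@H](Oc1cccc(F)c1F)C(=O)Nc1ccc2oc(-c3ccc(O)cc3)nc2c1` differs from compound 3 by 2,3-difluorophenyl in place of 2,3-dichlorophenyl on an oxygen on a saturated carbon. Among the measured compounds shown here, no measured step bears on this change: the two compounds carrying the 2,3-difluorophenoxy group and the one carrying the 2,3-dichlorophenoxy group all sit at the limit, as the limit of > 5000 nM in this assay, at which 3 of the 3 values shown sit, records. Given (the limit of > 5000 nM in this assay, at which 3 of the 3 values shown sit), compound 4 is expected to remain at or near the limit, with an estimated 20000 nM in this assay, ranging from 5000 nM to 100000 nM, which means an expected step that the limit leaves unreadable from compound 3 to compound 4.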

Compound 4, inhibition constant: > 5000 nM
Compound 4 ended at the assay's limit (the forecaster's own chance of this, stated with the estimate: 90%); the middle value lies beyond the limit too.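

No step among compound 1, compound 2, compound 3 and compound 4 can be read, since all four share one limit: the limit of > 5000 nM in this assay, at which 4 of the 4 values shown sit.

The compounds shown leave open whether 2,3-difluorophenoxy and 2,3-dichlorophenoxy, or the 4-methoxyphenyl, pyridin-4-yl and 4-hydroxyphenyl groups, differ at all in inhibition.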